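From Thiophene to Benzofuran at the Assay Limit

The source may report more compounds than this note shows. Statements on the series, on what has been measured and on what is new or still open speak of the compounds shown alone.

In an ADME assay on BJ cells (Homo sapiens), read by MTT assay, with a stated time of 72 h (a higher number here means a weaker inhibitor, a lower number a stronger inhibitor), compound 3 `COc1nc(N)nc2c1c(-c1ccsc1)cn2[C@@H]1O[C@H](CO)[C@@H](O)[C@H]1O` gives only a limit, > 100000 nM. Compound 2 `COc1nc(N)nc2c1c(-c1cccs1)cn2[C@@H]1O[C@H](CO)[C@@H](O)[C@H]1O`, which carries thiophen-2-yl instead, reads 99900 nM. Among the compounds with values here, the one measured step, a number no lower from compound 2 to compound 3 (the limit leaves the size open), has no readable size, so it offers little guidance. Compound 4 `COc1nc(N)nc2c1c(-c1cc3ccccc3o1)cn2[C@@H]1O[C@H](CO)[C@@H](O)[C@H]1O` carries 1-benzofuran-2-yl in place of thiophen-3-yl on an aromatic carbon. Compound 1 `Nc1nc(N)c2c(-c3cc4ccccc4o3)cn([C@@H]3O[C@H](CO)[C@@H](O)[C@H]3O)c2n1` bears the same 1-benzofuran-2-yl on a different core, and its reading is also a limit, > 100000 nM. No step beyond the usual scatter is therefore expected, and the estimated change is an at least 1.2-fold lower number from compound 3 to compound 4 (0.09 log units; that floor lies within the scatter). In this assay, the estimate for compound 4 is 80000 nM, within an expected range of 25000 nM to 100000 nM.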

Compound 4, half-maximal inhibitory concentration: 25600 nM
For compound 4 the middle estimate is 3.1-fold (0.49 log units) above the measured one, and the stated range covers the measured number.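

In this assay, within the data shown here, 1-benzofuran-2-yl on this aromatic carbon gives the first step of readable size at this position, a 3.9-fold lower number from compound 2 to compound 4 (0.59 log units; beyond the scatter). The same group gives an at least 3.9-fold lower number from compound 3 to compound 4 (0.59 log units; beyond the scatter), while methoxy on the core, with 1-benzofuran-2-yl kept, gives an at least 3.9-fold lower number from compound 1 to compound 4 (0.59 log units; beyond the scatter), so the group alone does not set the reading. Those last two steps start from a limit, so only their floors are known: the limit of > 100000 nM in this assay, at which 2 of the 4 values shown sit.

The compounds shown leave open whether the added six-membered aromatic ring or oxygen in place of sulfur carries the change. A furan-2-yl or a phenyl at this position would help separate the two.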